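The compounds below may be only part of what the source reports. "The series", "measured", "known", "first", "only" and "open" are said of these compounds alone.

Measured in a functional assay for inhibition, with Homo sapiens as the target; on this read-out higher numbers stand for weaker inhibition and lower numbers for stronger inhibition:
- compound 1 `Cc1cc2c(cc1C(=O)N=C(N)N)S(=O)(=O)CC2C(C)C`: 77 nM
- compound 2 `CC(C)=C1CS(=O)(=O)c2cc(C(=O)N=C(N)N)c(C)cc21`: 5030 nM
- compound 3 `Cc1cc2c(cc1C(=O)N=C(N)N)S(=O)(=O)C(C)(C)C2(C)O`: 102 nM

Compound 1, at 77 nM, lies within the usual scatter of compound 3, at 102 nM. Compound 2, at 5030 nM, stands well beyond that scatter from both, with a far higher number and so much weaker inhibition.

The next compound to be tested is compound 4 `Cc1cc2c(cc1C(=O)N=C(N)N)S(=O)(=O)CC2C`, which has methyl in place of isopropyl on a saturated ring carbon of compound 1 (methyl in place of isopropyl on a saturated ring carbon). Among the measured compounds shown here, no two measured compounds differ in a single place, so the data give no direct measure of this change. Compound 3, at 102 nM, carries no isopropyl and still gives a number close to that of compound 1, so a large loss seems unlikely. The expected step of a 1.9-fold higher number from compound 1 to compound 4 (0.29 log units; within the scatter) is a small one towards weaker inhibition, near the edge of the scatter. For compound 4 the estimated value is 150 nM. The expected range for compound 4 runs from 40 nM to 600 nM.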

Compound 4, half-maximal inhibitory concentration: 182 nM
Estimate against measurement, compound 4: 1.2-fold (0.08 log units) below; measured number inside the range.
By their numbers in this assay, from the lowest: compounds 1, 3 and 4 (each within the scatter of the next, the first and the last beyond it); then compound 2.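

In this assay, among the compounds shown here, this is the first direct measure of a change at this position: methyl in place of isopropyl on the saturated ring carbon gives a 2.4-fold higher number from compound 1 to compound 4 (0.37 log units; beyond the scatter) and so a modest move towards weaker inhibition. The position therefore responds to the group it carries, though inhibition is not lost when isopropyl gives way to methyl. The data shown offer no measurement that accounts for this difference.

With only isopropyl and methyl compared directly at this carbon, the compounds shown leave open how far the trend extends, for instance to an ethyl group, a longer chain such as n-butyl or a cyclopropyl ring. They also leave open what an amine, a carboxylic acid or a hydroxyl group would do in the same place on the shared core.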